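The compounds below may be only part of what the source reports. "The series", "measured", "known", "first", "only" and "open" are said of these compounds alone.

Of the compounds shown here, three sharing one core have been measured so far. In a functional assay on HL-60 cells (Homo sapiens) for inhibition, read by MTT assay, with a stated time of 48 h, tested at 10 uM (a lower number here means less inhibition of growth, a higher number more inhibition of growth at the concentration tested), compound 1 (`CCN(CC)Cc1c(O)c([C@H]2CCN(C)C[C@H]2O)c2oc(C)cc(=O)c2c1O`) gives 47% and carries diethylamino on a saturated chain carbon bound to an aromatic carbon. Compound 2 (`Cc1cc(=O)c2c(O)c(CN3CCC(N4CCCCC4)CC3)c(O)c([C@H]3CCN(C)C[C@H]3O)c2o1`) gives 34% in this assay as well. Compound 3 (`Cc1cc(=O)c2c(O)c(CN3CC(O)CC3C(=O)O)c(O)c([C@H]3CCN(C)C[C@H]3O)c2o1`) gives 28% in the same test. That places compound 3 within the scatter of compound 2 and clearly under compound 1.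

Compound 4 (`Cc1cc(=O)c2c(O)c(CN3CCCCC3)c(O)c([C@H]3CCN(C)C[C@H]3O)c2o1`) has not yet been measured. The change from compound 3 (piperidin-1-yl in place of 2-carboxy-4-hydroxypyrrolidin-1-yl on a saturated chain carbon bound to an aromatic carbon) puts piperidin-1-yl in place of 2-carboxy-4-hydroxypyrrolidin-1-yl on a saturated chain carbon bound to an aromatic carbon.

For the measured compounds named here, only one measured step bears directly on this change. It is a number 19 percentage points lower from compound 1 to compound 3 (beyond the scatter) and arose when 2-carboxy-4-hydroxypyrrolidin-1-yl took the place of diethylamino. Compound 4 gives up that same group, so a rise of similar or somewhat smaller size is expected. Going by the values given here, no measured step shows piperidin-1-yl itself entering, which leaves the estimate uncertain. The expected change is (a number 14 percentage points higher from compound 3 to compound 4 (beyond the scatter)). For compound 4 the expected value in this assay is 42% (estimated range 29% to 55%).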

Compound 4, percent growth inhibition at one concentration: 32%
Compound 4: the middle estimate sits 10 percentage points above what was measured; measured number inside the range.
By their numbers in this assay, from the lowest: compounds 3, 4 and 2 (each within the scatter of the next); then compound 1.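

In this assay, piperidin-1-yl on the saturated chain carbon bound to an aromatic carbon gives a number 4 percentage points higher from compound 3 to compound 4 (within the scatter), so this ring, which lacks the hydroxy and carboxy groups of 2-carboxy-4-hydroxypyrrolidin-1-yl, cannot be told apart from that group at this position. There is also a number 15 percentage points lower from compound 1 to compound 4 (beyond the scatter), which shows that the earlier gap to compound 1 is not confined to 2-carboxy-4-hydroxypyrrolidin-1-yl, since it appears with a plain piperidine ring too, while a number 2 percentage points lower from compound 2 to compound 4 (within the scatter) shows no readable effect from the piperidin-1-yl on the saturated ring carbon of compound 2. No measurement available here accounts for the way diethylamino stands apart from the three ring amines.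

Diethylamino is the only open-chain amine among these compounds, so it remains open whether the higher number belongs to open-chain amines in general or to this group alone. Dimethylamino or dipropylamino on the same carbon would test that, and morpholin-4-yl would show whether a further ring oxygen alone leaves the number where the other rings put it.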